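This account rests on a few compounds, and the source may have more. Where it says the series, first, only, none or still open, it means among the compounds named here.

Measured compounds:
- compound 1 `C/C(=N\Nc1ccccc1)c1c(O)c2ccccc2oc1=O`: 27000 nM
- compound 2 `C/C(=N\Cc1cccc(C)c1)c1c(O)c2ccccc2oc1=O`: 4900 nM
- compound 3 `C/C(=N\Cc1ccccn1)c1c(O)c2ccccc2oc1=O`: 22000 nM

These three numbers come from an assay on isolated protein for inhibition of myosin-2 (Bos taurus), read by spectrophotometry, with a stated time of 24 min; on this read-out lower numbers stand for stronger inhibition and higher numbers for weaker inhibition. Compound 3 stands second highest of the three: compound 1 sits within the scatter of it, as the step of a 1.2-fold lower number from compound 1 to compound 3 (0.09 log units; within the scatter) shows, while compound 2 sits clearly lower, by the step of a 4.5-fold higher number from compound 2 to compound 3 (0.65 log units; beyond the scatter). Compound 4 `CCCCC/N=C(\C)c1c(O)c2ccccc2oc1=O` differs from compound 3 by butyl in place of pyridin-2-yl on a saturated chain carbon bound to a double-bonded nitrogen. Within the data shown here, only the step from compound 2 to compound 3 touches the same position, and it was modest; no measured pair swaps a ring for a chain there. The expected step of a 1.2-fold lower number from compound 3 to compound 4 (0.09 log units; within the scatter) is therefore small and uncertain in direction. Compound 4 is estimated at 18000 nM, between 5000 nM and 60000 nM.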

Compound 4, half-maximal inhibitory concentration: 6700 nM
Estimate against measurement, compound 4: 2.7-fold (0.43 log units) above, and the stated range covers the measured number.
By their numbers in this assay, from the lowest: compounds 2 and 4 (each within the scatter of the next); then compounds 3 and 1 (each within the scatter of the next).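

Butyl, which carries no ring, shows that a ring is not needed on this saturated chain carbon bound to a double-bonded nitrogen: the change gives a 3.3-fold lower number from compound 3 to compound 4 (0.52 log units; beyond the scatter) and stays level with 3-methylphenyl in a 1.4-fold higher number from compound 2 to compound 4 (0.14 log units; within the scatter). The same holds on the double-bonded nitrogen itself, where pentyl in place of anilino gives a 4.0-fold lower number from compound 1 to compound 4 (0.61 log units; beyond the scatter). Nothing available explains these steps. As far as these compounds go, whether a longer chain such as octyl would go on as butyl does remains open. So does the effect of an amine or a carboxylic acid at the chain end.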